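This account rests on a few compounds, and the source may have more. Where it says the series, first, only, none or still open, it means among the compounds named here.

Measured compounds:

Compound 1, `O=C(O)[C@@H]1CCCN1C(=O)/C=C/c1ccncc1-c1ccc2ccccc2c1`, gives 67% in an assay on a protein complex for inhibition of CDK8/Cyclin C (Homo sapiens), with a stated time of 1 h, tested at 10 uM; a higher number here means more inhibition at the concentration tested (going by the name of the read-out), a lower number less inhibition.
Compound 2, `NNC(=O)CCc1ccncc1-c1ccc2ccccc2c1`, gives 102% in this assay.
Compound 3, `O=C(/C=C/c1ccncc1-c1ccc2ncccc2c1)N1CCOCC1`, gives 80% in this assay.

Among these three, compound 2 stands highest in this assay. Its nearest neighbour is compound 3, whose number is lower by a gap beyond the usual scatter, and compound 1 lies further below still, also beyond the scatter. Compound 2 thus stands apart from the other two on the numbers shown.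

Compound 4, `CCOC(=O)/C=C/c1ccncc1-c1ccc2ccccc2c1`, has not yet been measured. It differs from compound 2 in one place: 2-(ethoxycarbonyl)ethenyl in place of 2-(aminocarbamoyl)ethyl on an aromatic carbon. The group that leaves carries two hydrogen-bond donors; the group that enters carries none and brings one more double bond outside aromatic rings. Among the compounds with values here, no step between measured compounds tells how much such a change moves the number, so what follows is an expectation only. Compound 4 is expected to give 75% in this assay, within a range from 50% to 95%. The step of a number 27 percentage points lower from compound 2 to compound 4 (beyond the scatter) is expected to be a decrease beyond the scatter.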

Compound 4, a percentage reported as inhibition, at one concentration (the size of the read-out at that concentration, not a potency): 102%
For compound 4 the middle estimate is 27 percentage points below the measured one; measured number above the stated range.
By their numbers in this assay, from the lowest: compound 1; then compound 3; then compounds 2 and 4 (each within the scatter of the next).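

At the place opposite the ring nitrogen, 2-(ethoxycarbonyl)ethenyl can stand in for 2-(aminocarbamoyl)ethyl with no change at the digits printed from compound 2 to compound 4 (within the scatter) in this assay, even though the entering group has no hydrogen-bond donors and one more double bond outside aromatic rings. What sits on the carbonyl carbon of the ethenyl chain does matter, as ethoxy in place of 2-carboxypyrrolidin-1-yl gives a number 35 percentage points higher from compound 1 to compound 4 (beyond the scatter). No measured evidence accounts for either step.

The step to compound 4 changes the chain's double bond and its end group together, so the compounds shown cannot tell what each change does alone. From the compounds shown here alone, it also remains open whether the number would hold with a simple primary amide or a longer propoxy group on the carbonyl carbon.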